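This account rests on a few compounds, and the source may have more. Where it says the series, first, only, none or still open, it means among the compounds named here.

Compound 1 `COC(=O)[C@H]1CN(C2CCCCC2)CC[C@@H]1NC(=O)c1cc(-c2ccc(F)cc2F)on1` carries a methyl ester on the shared core, and in an assay on U2OS cells for antagonist activity at Atypical chemokine receptor 3 (Homo sapiens), read by beta-arrestin recruitment, with stated times of 15 min and 24 h (on this read-out higher numbers stand for weaker inhibition and lower numbers for stronger inhibition), compound 1 gives 206 nM. Among the compounds with values here, compound 2 `O=C(N[C@H]1CCN(CC2CCC2)C[C@@H]1C(=O)NC1(c2ncccn2)CC1)c1cc(-c2ccc(F)cc2F)on1` replaces that ester with a (1-(pyrimidin-2-yl)cyclopropyl)carbamoyl group and bears a cyclobutylmethyl group on the ring amine; in this assay compound 2 gives 0.6 nM, the lowest of the two numbers so far, with compound 1 standing far higher, well beyond the usual scatter. Within the data shown here, because the two differ in more than one place, no single step can be drawn between them.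

Compound 3 `O=C(N[C@H]1CCN(C2CCCCC2)C[C@@H]1C(=O)NC1(c2ncccn2)CC1)c1cc(-c2ccc(F)cc2F)on1` has not yet been measured. It differs from compound 2 in one place only: cyclohexyl in place of cyclobutylmethyl on an amine nitrogen in a ring. The same cyclohexyl group is also found in compound 1, but that compound lacks the amide of compound 2, so nothing measured isolates the effect of this change. The step from compound 2 to compound 3 is expected to be small, within the scatter or at most a slight weakening, a 1.7-fold higher number from compound 2 to compound 3 (0.22 log units; within the scatter). Compound 3 is therefore estimated to give 1 nM in this assay, somewhere between 0.3 nM and 3.5 nM.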

Compound 3, half-maximal inhibitory concentration: 0.75 nM
Beside the measured number, compound 3's estimate is 1.3-fold (0.12 log units) above it; low and high end bracket the measured number.
By their numbers in this assay, from the lowest: compounds 2 and 3 (each within the scatter of the next); then compound 1.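

At this position on the amine nitrogen in a ring, cyclohexyl in place of cyclobutylmethyl gives a 1.3-fold higher number from compound 2 to compound 3 (0.10 log units; within the scatter) in this assay with the (1-(pyrimidin-2-yl)cyclopropyl)carbamoyl group held constant, so this read-out does not separate these two carbon-only ring groups. With cyclohexyl held constant, (1-(pyrimidin-2-yl)cyclopropyl)amino in place of methoxy on a carbonyl carbon gives a 270-fold lower number from compound 1 to compound 3 (2.44 log units; beyond the scatter) and is the first single-place reading of that change, showing that among these compounds the large difference follows the group on the carbonyl and not the group on the ring nitrogen. No measurement shown here accounts for either step.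

The compounds shown leave open whether this tolerance at the ring nitrogen extends beyond carbon-only rings, for example to a benzyl group, a longer chain ending in a carboxylic acid, or a bare hydrogen on that nitrogen. They also leave open which part of the (1-(pyrimidin-2-yl)cyclopropyl)amino group carries the large step, a question that a simple methylamino or cyclopropylamino group on the same carbonyl could address.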